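Chloro for hydrogen on the fused core: compound 2 to compound 4

A few compounds are considered here, and "the series" means these few. Any claim that something is new, unique, unknown or untested is made for them only; others in the source may bear on it.

Compound 1 `ClCc1ccccc1Cn1cnc2c(Cl)ncnc21` gives 8910 nM in a functional assay on IGROV-1 cells (Homo sapiens) for cytotoxicity, read by sulforhodamine B assay, with a stated time of 48 h; a lower number here means a stronger inhibitor of growth, a higher number a weaker inhibitor of growth. Compound 2 `ClCc1cccc(Cn2cnc3ncnc(Cl)c32)c1` gives 13800 nM in this assay, the highest of the three numbers; it sits within the scatter of compound 1 and beyond it from compound 3 `ClCc1cccc(Cn2cnc3c(Cl)nc(Cl)nc32)c1`, which gives 5120 nM in this assay. Compound 4 `ClCc1cccc(Cn2cnc3nc(Cl)nc(Cl)c32)c1` differs from compound 2 by chloro in place of hydrogen on an aromatic carbon, a chloro in place of hydrogen on an aromatic carbon. For the measured compounds named here, no measured pair shows this exact change; compound 3 carries a second chloro and gives the lowest number, so a modest move toward a lower number is expected, about at the edge of the scatter. Compound 4 is expected to give 6500 nM, between 2700 nM and 15000 nM, a step of a 2.1-fold lower number from compound 2 to compound 4 (0.33 log units; beyond the scatter) that is estimated.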

Compound 4, concentration for total growth inhibition: 30900 nM
For compound 4 the middle estimate is 4.8-fold (0.68 log units) below the measured one; the whole stated range lies below it.
By their numbers in this assay, from the lowest: compounds 3, 1 and 2 (each within the scatter of the next, the first and the last beyond it); then compound 4.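

In this assay, for the compounds shown here, the step of a 2.2-fold higher number from compound 2 to compound 4 (0.35 log units; beyond the scatter) is the first single-place change that can be read. At this carbon, between two ring nitrogen atoms, chloro in place of hydrogen gives a weaker inhibitor of growth, though the step is modest. Nothing measured here accounts for the step.

From the compounds shown here alone, whether an amine or a methoxy group on the same carbon would move the number in the same direction remains open. Going by these compounds alone, with only one pair carrying this change, its size elsewhere is also unknown.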